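Changing the carboxy-bearing group of compound 3

The source may hold more compounds than are shown below. What is called first, only, known or untested is meant among the compounds shown, and "the series" means these compounds.

Values in a functional assay on Caco-2 cells (Homo sapiens) for antiproliferative activity, read by MTT assay, with a stated time of 48 h; a higher number here means a weaker inhibitor, a lower number a stronger inhibitor:
Compound 1 `CCn1c(C(=O)N(CCC#N)CCC#N)ccc1C(CC)(CC)c1ccc(OCCC(O)(CC)CC)c(C)c1`: > 50000 nM, a limit
Compound 2 `C=CCN(C)C(=O)c1ccc(C(CC)(CC)c2ccc(OCCC(O)(CC)CC)c(C)c2)n1CC`: > 50000 nM, a limit
Compound 3 `CCC(C)C(NC(=O)c1ccc(C(CC)(CC)c2ccc(OCCC(O)(CC)CC)c(C)c2)n1CC)C(=O)O`: 20000 nM

Among the measured compounds shown here, compound 3, at 20000 nM, holds the only actual number in this small set, and it is the most active of the three. Compound 4 `CCn1c(C(=O)N(C)CC(=O)O)ccc1C(CC)(CC)c1ccc(OCCC(O)(CC)CC)c(C)c1` has (carboxymethyl)(methyl)amino in place of (1-carboxy-2-methylbutyl)amino on the same carbonyl carbon. The counted difference is (carboxymethyl)(methyl)amino in place of (1-carboxy-2-methylbutyl)amino on a carbonyl carbon.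

Two measured steps at this carbonyl carbon bear on the change: an at least 2.5-fold lower number from compound 1 to compound 3 (0.39 log units; beyond the scatter), and an at least 2.5-fold lower number from compound 2 to compound 3 (0.39 log units; beyond the scatter). The third, a step that the two limits leave unreadable from compound 1 to compound 2, gives no usable size. Among the three measured compounds, only compound 3 carries a carboxy group. Compound 4 keeps a carboxy group, so it is expected to stay near compound 3 at 20000 nM. Its new group also shares a methyl with the allyl(methyl)amino of compound 2, which sits at > 50000 nM, a limit. A slight drift towards a higher number in this assay therefore seems more likely than a gain.

The expected result is a 1.3-fold higher number from compound 3 to compound 4 (0.10 log units; within the scatter), which would not be a change beyond the scatter. For compound 4 the estimated value is 25000 nM, with an expected range from 10000 nM to 50000 nM.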

Compound 4, half-maximal inhibitory concentration: 2740 nM
Compound 4: the middle estimate sits 9.1-fold (0.96 log units) above what was measured; the whole stated range lies above it.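

In this assay, having a carboxy group on this carbonyl carbon does not fix the level of activity, as compound 3 and compound 4 both have one, yet replacing (1-carboxy-2-methylbutyl)amino with (carboxymethyl)(methyl)amino gives a 7.3-fold lower number from compound 3 to compound 4 (0.86 log units; beyond the scatter). Measured against the two amides without a carboxy group, the same group gives an at least 18-fold lower number from compound 2 to compound 4 (1.26 log units; beyond the scatter) and an at least 18-fold lower number from compound 1 to compound 4 (1.26 log units; beyond the scatter), so this position allows much more activity than compound 3 alone revealed. Both of these larger steps start from a limit, for compound 1 and for compound 2, rather than from a number, so their true sizes remain unknown: the limit of > 50000 nM in this assay, at which 2 of the 4 values shown sit.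

The step from compound 3 to compound 4 shortens the chain, adds a methyl on the amide nitrogen and removes the amide hydrogen all at once, and a plain (carboxymethyl)amino group would help to separate these changes. From the compounds shown here alone, it also remains open how a longer chain between the amide nitrogen and the carboxylic acid, or a methyl ester in place of that acid, would read in this assay.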